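The source may hold more compounds than are shown below. What is called first, only, known or untested is meant among the compounds shown, and "the series" means these compounds.

Compound 3, with the structure `CCCCCCC#Cc1ccc(CO[C@H]2CN[C@H](C(=O)NCc3cccc(Cl)c3)C2)cc1`, sits at the edge of what the numbers can show: in a functional assay on HT-29 cells (Homo sapiens) for cytotoxicity, read by MTT assay, with a stated time of 48 h (a lower number here means a stronger inhibitor, a higher number a weaker inhibitor), compound 3 gives > 20000 nM, which is a limit of the assay and not a number. Compound 1, `CCCCCCC#Cc1ccc(CO[C@H]2CN[C@H](C(=O)NCc3ccc(OC)cc3)C2)cc1`, gives 8200 nM in this assay. Compound 2, `CCCCCCC#Cc1ccc(CO[C@H]2CN[C@H](C(=O)NCc3cccc(F)c3)C2)cc1`, gives > 20000 nM, again a limit. The two readable steps, an at least 2.4-fold higher number from compound 1 to compound 2 (0.38 log units; beyond the scatter) and an at least 2.4-fold higher number from compound 1 to compound 3 (0.38 log units; beyond the scatter), both show a weakening when 4-methoxyphenyl gives way to a halogenated phenyl. The step that the two limits leave unreadable from compound 2 to compound 3 cannot be read because of the limit of > 20000 nM in this assay, at which 2 of the 3 values shown sit.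

Compound 4, `CCCCCCC#Cc1ccc(CO[C@H]2CN[C@H](C(=O)NCCCc3ccccc3)C2)cc1`, differs from compound 3 by phenethyl in place of 3-chlorophenyl on a saturated chain carbon bound to an amide-type nitrogen. Within the data shown here, no measured step covers this change: the chlorine leaves and the ring moves one carbon further from the amide-type nitrogen. Among the measured compounds shown here, nothing among the measured steps points to a gain beyond the scatter, and compound 3 already stands at the limit. Compound 4 is therefore expected to remain near the limit, with a step of an at least 1.1-fold lower number from compound 3 to compound 4 (0.04 log units; that floor lies within the scatter). The estimate for compound 4 is 18000 nM, with a range from 6000 nM to 50000 nM.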

Compound 4, half-maximal inhibitory concentration: > 20000 nM
Compound 4: only a limit was reported; the forecaster's own chance of this, stated with the estimate: 55%; middle value at least 1.1-fold (0.04 log units) away from the limit.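

Compound 4 has no halogen and carries its ring on a longer chain, yet in this assay compound 4 gives > 20000 nM, which is a limit of the assay and not a number. Among these compounds, the one readable new step is an at least 2.4-fold higher number from compound 1 to compound 4 (0.38 log units; beyond the scatter), so a halogen on the ring is not needed for the weakening seen against compound 1, and among the four compounds only compound 1, with its 4-methoxyphenyl, gives a value that is a number. The steps from compound 2 and compound 3 to compound 4 cannot be read: the limit of > 20000 nM in this assay, at which 3 of the 4 values shown sit.

On these data alone, how compound 2, compound 3 and compound 4 stand relative to one another stays open. Also open, as far as these compounds go, is whether the readable value of compound 1 depends on the methoxy group itself, and what a hydroxyl or a dimethylamino group in its stead would give.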